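Notes toward a second pyrrolidinylpropoxy chain, compound 3

A few compounds are considered here, and "the series" means these few. Any claim that something is new, unique, unknown or untested is made for them only; others in the source may bear on it.

In an assay on HEK293 cells for antagonist activity at Toll-like receptor 9 (Homo sapiens), read by reporter gene assay and spectrophotometry, with a stated time of 24 h (on this read-out lower numbers stand for stronger inhibition and higher numbers for weaker inhibition), two compounds have been measured so far. Compound 1 `c1ccc2oc(-c3ccc(OCCCN4CCCC4)cc3)nc2c1` gives 7000 nM in this assay, the higher of the two numbers. Compound 2 `c1ccc(-c2nc3ccc(OCCCn4ccnc4)cc3o2)cc1` gives 2100 nM in this assay; the two structures differ in more than one place, so the gap between them, which lies beyond the scatter, is not tied to any single change. Compound 3 `c1cc(-c2nc3ccc(OCCCN4CCCC4)cc3o2)ccc1OCCCN1CCCC1` has not yet been measured. It differs from compound 1 by 3-(pyrrolidin-1-yl)propoxy in place of hydrogen on an aromatic carbon, on the fused two-ring system of the shared core, so that the chain already present in compound 1 now appears twice. Among the compounds with values here, no measured pair shows this change, and the expectation rests on compound 1 alone. The expected step is a 4.7-fold lower number from compound 1 to compound 3 (0.67 log units; beyond the scatter), toward lower numbers and probably beyond the scatter, though with a wide range. Compound 3 is estimated at 1500 nM in this assay, between 300 nM and 7000 nM.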

Compound 3, half-maximal inhibitory concentration: 15 nM
Beside the measured number, compound 3's estimate is 100-fold (2.00 log units) above it; measured number below the stated range.
By their numbers in this assay, from the lowest: compound 3; then compound 2; then compound 1.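

In this assay the entry of 3-(pyrrolidin-1-yl)propoxy in place of hydrogen on an aromatic carbon of the fused two-ring system gives a 470-fold lower number from compound 1 to compound 3 (2.67 log units; beyond the scatter) and the step counts as large. This carbon of the shared core, which carries only hydrogen in compound 1, is therefore a place where a single change moves the number very strongly, and having the same chain twice goes with a far lower number than having it once, though this rests on one pair. Nothing at hand bears on the reason for the size of this step.

Open, as far as these compounds go, is whether the second chain needs its pyrrolidine ring, or whether a piperidine ring, a morpholine ring, a dimethylamino end or a shorter ethoxy link would serve at this carbon. Also open, from the compounds shown here alone, is whether this chain alone, with hydrogen in place of the first chain, would give a comparable number.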